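This account rests on a few compounds, and the source may have more. Where it says the series, first, only, none or still open, it means among the compounds named here.

Compound 2 `COc1ccc(-c2cc3[nH]nc(-c4cc(OC)c(OC)c(OC)c4)n3n2)cc1[N+](=O)[O-]` carries a nitro group on an aromatic carbon of the shared core, where compound 1 `COc1ccc(-c2cc3[nH]nc(-c4cc(OC)c(OC)c(OC)c4)n3n2)cc1` carries a hydrogen. In a functional assay on A549 cells (Homo sapiens) for antiproliferative activity, read by MTT assay, with a stated time of 72 h (a higher number here means a weaker inhibitor, a lower number a stronger inhibitor), compound 1 gives 26400 nM, and in this assay compound 2 gives 58200 nM. Among the measured compounds shown here, compound 2 thus stands highest of the two numbers so far, and the only other number, that of compound 1, lies below it by the step of a 2.2-fold higher number from compound 1 to compound 2 (0.34 log units; beyond the scatter), the change being nitro in place of hydrogen on an aromatic carbon. Compound 3 `COc1ccc(-c2cc3[nH]nc(-c4cc(OC)c(OC)c(OC)c4)n3n2)cc1N` has not yet been measured; it differs from compound 2 by amino in place of nitro on an aromatic carbon. For the measured compounds named here, only one measured step touches this change, and only in part: it shows what adding a nitro group to compound 1 did, while no measured step shows what an amino group at the same place does. Because a 2.2-fold higher number from compound 1 to compound 2 (0.34 log units; beyond the scatter) came with the nitro group, removing that group is expected to bring the number for compound 3 back toward that of compound 1, an expected step of a 1.9-fold lower number from compound 2 to compound 3 (0.29 log units; within the scatter). Compound 3 is therefore estimated at 30000 nM in this assay, within a range from 12000 nM to 75000 nM.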

Compound 3, half-maximal inhibitory concentration: 17400 nM
Beside the measured number, compound 3's estimate is 1.7-fold (0.24 log units) above it; measured number inside the range.
By their numbers in this assay, from the lowest: compounds 3 and 1 (each within the scatter of the next); then compound 2.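

Among the compounds shown here, the earlier compounds showed only that a nitro group at this place, ortho to a methoxy group, came with a higher number than hydrogen; in this assay, amino in place of nitro now gives a 3.3-fold lower number from compound 2 to compound 3 (0.52 log units; beyond the scatter), so the read-out depends on which group sits here and not merely on whether the place is filled. Amino in place of hydrogen gives a 1.5-fold lower number from compound 1 to compound 3 (0.18 log units; within the scatter), so this assay does not separate the amino group from hydrogen, and among the three compounds nitro alone stands apart, beyond the scatter from both of the others. Nothing measured here accounts for the gap between the nitro and amino compounds.

The compounds shown do not tell whether any group at this place can bring the number clearly below that of compound 1, since amino, the only other group here, stays within the scatter of hydrogen. A hydroxyl group, a fluorine atom, a dimethylamino group or an acetamide at the same place could show whether the higher number stays unique to nitro or is shared by other groups.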